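Methoxy for Methylsulfanyl on the Pyrimidine Thiourea

This account rests on a few compounds, and the source may have more. Where it says the series, first, only, none or still open, it means among the compounds named here.

Three compounds have been measured in a functional assay on the whole organism for inhibition, with Brassica napus as the target, with a stated time of 72 h, tested at 10 mg/L; a higher number here means more inhibition of growth at the concentration tested, a lower number less inhibition of growth:
compound 1, `CSc1cc(C)nc(NC(=S)NC(=O)c2c(-c3ccc(Cl)cc3Cl)noc2C)n1`, gives 42.4%
compound 2, `Cc1onc(-c2ccc(Cl)cc2Cl)c1C(=O)/N=c1/nc2nc(Cl)cc(C)n2s1`, gives 20.1%
compound 3, `COc1cc(OC)n2s/c(=N\C(=O)c3c(-c4ccc(Cl)cc4Cl)noc3C)nc2n1`, gives 49.3%

Compound 1 stands second highest of the three numbers. Its number and that of compound 3 lie within the usual scatter of each other, while compound 2 lies beyond the scatter below compound 1. Compound 4, `COc1cc(C)nc(NC(=S)NC(=O)c2c(-c3ccc(Cl)cc3Cl)noc2C)n1`, has not yet been measured in this assay. It differs from compound 1 by methoxy in place of methylsulfanyl on an aromatic carbon. Within the data shown here, no step between measured compounds shows the effect of this exchange alone. Since compound 3 carries methoxy groups and gives 49.3%, the exchange is expected to bring no step beyond the scatter. The expected step is a number 0.4 percentage points lower from compound 1 to compound 4 (within the scatter). Compound 4 is expected to give 42%, with a range from 26% to 58%.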

Compound 4, percent growth inhibition at one concentration: 15.7%
The estimate for compound 4 lay 26.3 percentage points above the measured number; the whole stated range lies above it.
By their numbers in this assay, from the lowest: compounds 4 and 2 (each within the scatter of the next); then compounds 1 and 3 (each within the scatter of the next).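

In this assay, among these compounds, methoxy in place of methylsulfanyl on this aromatic carbon brings a number 26.7 percentage points lower from compound 1 to compound 4 (beyond the scatter), a step that no pair among the earlier compounds could show. Both groups hold 2 heavy atoms, so at this position the change from sulfur to oxygen alone separates the two numbers. Nothing measured here gives a reason for the step. The compounds shown leave open whether a longer chain on the sulfur, such as ethylsulfanyl, would hold the level of compound 1. They also leave open how an amine at this position would compare.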